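Two Stereoisomers Measured, a Third Ring Configuration Awaited

The compounds below may be only part of what the source reports. "The series", "measured", "known", "first", "only" and "open" are said of these compounds alone.

Compound 1 `c1ccc(CNCC[C@H]2CCC[C@H](c3ccccc3)C2)cc1`: 1.4 nM
Compound 2 `NCC[C@H]1CCC[C@@H](c2ccccc2)C1`: 138 nM
Compound 3 `NCC[C@@H]1CCC[C@H](c2ccccc2)C1`: 167 nM

The three measured compounds share one saturated ring carrying a phenyl group and an aminoethyl side chain. In an assay on membranes from brain for displacement of a labelled ligand from Sigma non-opioid intracellular receptor 1 (Cavia porcellus), read by scintillation counting, with a stated time of 120 min (on this read-out lower numbers stand for stronger inhibition and higher numbers for weaker inhibition), compound 1 gives 1.4 nM and carries a benzyl group on its nitrogen, whereas compound 2 and compound 3 are the free primary amines. Compound 3 has the highest number of the three; it sits closest to compound 2, and far from compound 1.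

Within the data shown here, the one measured step that bears on configuration is a 1.2-fold higher number from compound 2 to compound 3 (0.08 log units; within the scatter). Both stereocentres are inverted there, so compound 2 and compound 3 are mirror images, and the numbers stay within the scatter. That is the weight of the fact that compounds 2 and 3 differ only in the configuration as drawn.

Compound 4 `NCC[C@H]1CCC[C@H](c2ccccc2)C1` differs from compound 3 only in this way: the two compounds have the same atoms and bonds and differ only in configuration as drawn: 1 of 2 stereo elements differ; a stereocentre at a saturated ring carbon is drawn R in compound 3 and S in compound 4. Only one of the two centres changes. Compound 4 is thus not a mirror image of compound 3 but a different relative arrangement of phenyl and side chain on the ring. Among the measured compounds shown here, no measured step covers that kind of change; the mirror-image step says nothing direct about it. The estimate for compound 4 is therefore close to compound 3, expected at 110 nM within 25 nM to 450 nM, a step of a 1.5-fold lower number from compound 3 to compound 4 (0.18 log units; within the scatter) that is essentially none beyond the scatter, with a wide range to allow for the untested relative configuration.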

Compound 4, inhibition constant: 603 nM
Beside the measured number, compound 4's estimate is 5.5-fold (0.74 log units) below it, and the stated range ends below it.
By their numbers in this assay, from the lowest: compound 1; then compounds 2 and 3 (each within the scatter of the next); then compound 4.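

In this assay, the relative arrangement of phenyl and side chain matters in a way the mirror-image pair could not show: changing one of the two centres gives a 3.6-fold higher number from compound 3 to compound 4 (0.56 log units; beyond the scatter) and a 4.4-fold higher number from compound 2 to compound 4 (0.64 log units; beyond the scatter), whereas inverting both had left the numbers within the scatter. The atoms and bonds stay the same, so these modest steps rest on configuration alone: the fact that compounds 3 and 4 differ only in the configuration as drawn. Among these compounds, the configuration of compound 4 is also the one drawn for compound 1, and with hydrogen in place of benzyl on the amine nitrogen the change is far larger, at a 430-fold higher number from compound 1 to compound 4 (2.63 log units; beyond the scatter), so this single ring centre moves the number much less than that substituent does.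

What the mirror image of compound 4 would give remains open, and with only one configuration shown carrying the benzyl group, so does whether that group would have the same effect on the configurations of compound 2 and compound 3. Equally open, as far as these compounds go, is how a methyl group on the nitrogen, a phenethyl group there or a longer chain in place of the aminoethyl side chain would compare.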